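The source may report more compounds than this note shows. Statements on the series, on what has been measured and on what is new or still open speak of the compounds shown alone.

Measured so far:
- compound 1, `COc1cc(N2C(N)=C(C#N)C(c3c(OC)ccc4ccccc34)C3=C2CC(C)(C)CC3=O)cc(OC)c1OC`: 30%
- compound 2, `COc1ccccc1C1C(C#N)=C(N)N(c2cc(OC)c(OC)c(OC)c2)C2=C1C(=O)CC(C)(C)C2`: 100%

In a functional assay on Ehrlich cells (Mus musculus) for cytotoxicity, tested at 100 ug/mL (on this read-out higher numbers stand for a stronger effect at the one concentration tested and lower numbers for a weaker effect), compound 2 gives 100%, the higher of the two numbers; compound 1 gives 30%. Going by the values given here, the one measured step, a number 70 percentage points higher from compound 1 to compound 2 (beyond the scatter), swapped a 2-methoxyphenyl in for a 2-methoxynaphthalen-1-yl on a saturated ring carbon of the shared core, so the smaller aryl group went with the much stronger effect.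

Compound 3, `COc1cc(N2C(N)=C(C#N)C(c3ccccc3)C3=C2CC(C)(C)CC3=O)cc(OC)c1OC`, is the next member: hydrogen in place of methoxy on an aromatic carbon. Among the compounds with values here, no measured step removes a methoxy from this aryl ring, so there is no direct guide. Within the data shown here, the only related step is the trimming of the aryl group from compound 1 to compound 2, which was large and upward; compound 3 trims it further. Compound 2 already sits at the top of the scale in this assay, so no rise can be seen, and a small drop would still lie within the scatter. Compound 3 is therefore expected to stay close, with a number 15 percentage points lower from compound 2 to compound 3 (beyond the scatter), and its estimated value is 85%, in the range from 55% to 100%.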

Compound 3, a percentage reported as activity, at one concentration (the size of the read-out at that concentration, not a potency): 10%
Compound 3: the middle estimate sits 75 percentage points above what was measured; measured number below the stated range.
By their numbers in this assay, from the lowest: compound 3; then compound 1; then compound 2.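

In this assay, the change from 2-methoxyphenyl to phenyl gives a number 90 percentage points lower from compound 2 to compound 3 (beyond the scatter) and so shows that this one methoxy, ortho to a large group on the aromatic ring, has a large bearing on the result. Shrinking the aryl group on the saturated ring carbon therefore does not simply raise the number: the earlier step pointed upward, yet going all the way to phenyl gives a number 20 percentage points lower from compound 1 to compound 3 (beyond the scatter) and leaves the 2-methoxynaphthalen-1-yl compound in the middle, with the 2-methoxyphenyl compound on top. Nothing available here explains why removing this methoxy has so large an effect.

Still open, going by these compounds, is whether a hydroxy group, a chlorine atom or an ethoxy group in the same place would keep the number near that of compound 2 or let it fall toward that of compound 3. Also open, on these data alone, is whether a methoxy group elsewhere on this ring would do the same, and, with only one concentration read, how these compounds compare in potency.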